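The compounds below may be only part of what the source reports. "The series", "measured", "known", "first", "only" and "open" are said of these compounds alone.

Measured compounds in a functional assay on the whole organism with Rattus norvegicus as the target; a higher number here means that more compound is needed for the effect, a lower number that less compound is needed:

Compound 1 `Cc1ccc(NN=C2CCC(C)n3c2ncc(C(=O)O)c3=O)cc1C`. In this assay compound 1 reaches only a limit, > 100 umol/kg.
Compound 2 `Cc1cc(C)cc(NN=C2CCC(C)n3c2ncc(C(=O)O)c3=O)c1`. In this assay compound 2 reaches only a limit, > 320 umol/kg.
Compound 3 `CC1CCC(=NNc2ccc(Cl)cc2Cl)c2ncc(C(=O)O)c(=O)n21`. In this assay compound 3 reaches only a limit, > 100 umol/kg.

Compound 3 therefore stands at a limit rather than at a number, and the other two values shown are limits as well, so no ranking among compounds 1, 2 and 3 can be read. The steps between them, a step that the two limits leave unreadable from compound 1 to compound 2, a step that the two limits leave unreadable from compound 1 to compound 3 and a step that the two limits leave unreadable from compound 2 to compound 3, are all of unreadable size for the same reason; the supporting evidence is only the limit of > 100 umol/kg in this assay, at which 2 of the 3 values shown sit, and (the limit of > 320 umol/kg in this assay, at which 1 of the 3 values shown sits).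

Compound 4 `CC1CCC(=NNc2cc(Cl)cc(Cl)c2)c2ncc(C(=O)O)c(=O)n21` is the next compound. The change from compound 3 is 3,5-dichlorophenyl in place of 2,4-dichlorophenyl on an amine nitrogen. All three measured steps bear on it, since each is a change of the aryl group on the same amine nitrogen, but none of them gives a readable size. No step beyond the scatter can be expected in this assay from this evidence; the step that the limit leaves unreadable from compound 3 to compound 4 is the estimate that follows. Compound 4 is expected to give 200 umol/kg in this assay, most likely again as a limit, within 60 umol/kg to 1000 umol/kg.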

Compound 4, dose for 50% inhibition: > 100 umol/kg
Compound 4 was reported as a limit (the forecaster's own chance of this, stated with the estimate: 80%); the middle value is on the limit's open side.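

In this assay compound 4 gives > 100 umol/kg, which is a limit. No step between compound 4 and compound 1, compound 2 or compound 3 can be read from it: the limit of > 100 umol/kg in this assay, at which 3 of the 4 values shown sit.

The compounds shown leave open what dose gives the effect for any of these aryl groups on the amine nitrogen, and whether changing the aryl group shifts that dose at all.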